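A few compounds are considered here, and "the series" means these few. Any claim that something is new, unique, unknown or untested is made for them only; others in the source may bear on it.

Compound 1, `C=C(C)CCOC(=O)C[C@@H]1C(C(=O)OC)=CO[C@@H](O[C@@H]2O[C@H](COC(C)=O)[C@@H](OC(C)=O)[C@H](OC(C)=O)[C@H]2OC(C)=O)/C1=C/C`, is reported in a functional assay on SK-BR-3 cells (Homo sapiens) for antiproliferative activity, read by MTT assay, with a stated time of 72 h (a higher number here means a weaker inhibitor, a lower number a stronger inhibitor), only as the limit > 15000 nM. Compound 2, `C/C=C1/[C@H](O[C@@H]2O[C@H](CO)[C@@H](O)[C@H](O)[C@H]2O)OC=C(C(=O)OC)[C@H]1CC(=O)OCCCCCCCCCCCCCCC`, gives 1600 nM in this assay. Compound 3, `C/C=C1/[C@H](O[C@@H]2O[C@H](CO)[C@@H](O)[C@H](O)[C@H]2O)OC=C(C(=O)OC)[C@H]1CC(=O)OCCCc1ccc(OC)c(OC)c1`, is reported in this assay only as the limit > 20000 nM.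

Compound 3 therefore stands at a limit rather than a number, and one other compound among the three also sits at a limit. Among the measured compounds shown here, the one measured step that bears on it is an at least 12-fold higher number from compound 2 to compound 3 (1.09 log units; beyond the scatter), a large loss that ended at the limit of > 20000 nM in this assay, at which 1 of the 3 values shown sits. Compound 4, `C/C=C1/[C@H](O[C@@H]2O[C@H](CO)[C@@H](O)[C@H](O)[C@H]2O)OC=C(C(=O)OC)[C@H]1CC(=O)OCc1ccc(OC)c(OC)c1`, differs from compound 3 by 3,4-dimethoxyphenyl in place of 2-(3,4-dimethoxyphenyl)ethyl on a saturated chain carbon bound to an oxygen next to a carbonyl group. For the measured compounds named here, no measured step shortens this chain, so the expectation for compound 4 rests on compound 3 alone, and the step of a number no higher from compound 3 to compound 4 (the limit leaves the size open) is expected to stay within the scatter. Compound 4 is estimated at 20000 nM, in the range 7000 nM to 60000 nM.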

Compound 4, half-maximal inhibitory concentration: > 15000 nM
Compound 4: only a limit was reported; the forecaster's own chance of this, stated with the estimate: 70%; the middle value lies beyond the limit too.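

In this assay compound 4 is reported only as the limit > 15000 nM. Among the compounds shown here, compound 3 is also reported only as a limit, > 20000 nM, so no step between the two can be read. The compounds shown leave open whether compound 3 and compound 4 differ in activity at all.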